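The compounds below may be only part of what the source reports. "The series", "measured", "known", "first", "only" and "open" are said of these compounds alone.

Working notes on the series

Compound 1 `O=S(=O)(c1ccc(-c2cnc(C3CC3)o2)cc1)N1CCCOc2ccccc21` is the reference point of this set. In a functional assay on HepG2 cells (Homo sapiens) for antiproliferative activity, read by MTT assay, with a stated time of 72 h (on this read-out lower numbers stand for stronger inhibition and higher numbers for weaker inhibition), compound 1 gives 40 nM, the lowest of the three numbers recorded so far. Within the data shown here, compound 3 `O=[N+]([O-])c1ccc2c(c1)OCCCN2S(=O)(=O)c1ccc(-c2cnc(C3CC3)o2)cc1` gives 71 nM; the step of a 1.8-fold higher number from compound 1 to compound 3 (0.25 log units; within the scatter) is the only single-point change that has been measured, and it is within the scatter. Among the measured compounds shown here, compound 2 `O=S(=O)(c1ccc(-c2cnc(C3CC3)o2)cc1)N1CCOCc2ccccc21` gives 242 nM, a higher number than compound 1, and that gap lies beyond the scatter; no single-point step connects these two compounds, so only the two values themselves are on hand.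

Compound 4 `COc1ccc2c(c1)N(S(=O)(=O)c1ccc(-c3cnc(C4CC4)o3)cc1)CCCO2` is not yet measured. It differs from compound 1 as follows: methoxy in place of hydrogen on an aromatic carbon. For the measured compounds named here, the only measured step that bears on this change is a 1.8-fold higher number from compound 1 to compound 3 (0.25 log units; within the scatter) and there the number moved within the scatter. A second substituent on an aromatic carbon of the same fused system is therefore expected to leave the number close to where compound 1 sits, with no step beyond the scatter in either direction, a 1.5-fold higher number from compound 1 to compound 4 (0.18 log units; within the scatter) being the expected step. For compound 4 the estimate is 60 nM, with a range from 25 nM to 150 nM.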

Compound 4, half-maximal inhibitory concentration: 49 nM
Beside the measured number, compound 4's estimate is 1.2-fold (0.09 log units) above it; low and high end bracket the measured number.
By their numbers in this assay, from the lowest: compounds 1, 4 and 3 (each within the scatter of the next); then compound 2.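

Replacing hydrogen with methoxy on this aromatic carbon, meta to a fused ring and para to a fused ring, gives a 1.2-fold higher number from compound 1 to compound 4 (0.09 log units; within the scatter) in this assay, so this change leaves the number of compound 1 effectively unmoved. Until now, the only measured substitution on this aromatic ring was nitro, with a 1.8-fold higher number from compound 1 to compound 3 (0.25 log units; within the scatter); there are now two different groups, each with a step within the scatter, although this pattern rests on compound 3 and compound 4 alone and no compound shown goes against it. Nothing on hand explains why the number holds with methoxy at this carbon.

The compounds shown leave open whether an amine, a carboxylic acid or a longer alkoxy chain such as butoxy on this same carbon would also stay within the scatter of compound 1, so the limit of what this carbon accepts remains unknown. They also leave open whether methoxy would give a similarly small step on the core of compound 2, whose number lies beyond the scatter from that of compound 1.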